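Chloro for tert-butyl at the amide aryl end

The source may hold more compounds than are shown below. What is called first, only, known or untested is meant among the compounds shown, and "the series" means these compounds.

Compound 2 `CCOC(=O)c1sc(-c2cccc(NC(=O)c3ccc(C(C)(C)C)cc3)c2)nc1Nc1ccc(N2CCN(C)CC2)cc1` gives 21.2% in a functional assay on Ramos cells (Homo sapiens) for antiproliferative activity, read by CCK-8 assay, with a stated time of 72 h, tested at 40 uM (on this read-out lower numbers stand for less inhibition and higher numbers for more inhibition at the one concentration tested (going by the name of the read-out)), second highest of the three numbers; compound 1 `CCOC(=O)c1sc(-c2cccc(NC(=O)c3ccc(C(F)(F)F)cc3)c2)nc1Nc1ccc(N2CCN(C)CC2)cc1` with 18.4% sits nearest, within the scatter, while compound 3 `CCOC(=O)c1sc(-c2cccc(NC(=O)c3cccc(F)c3)c2)nc1Nc1ccc(N2CCN(C)CC2)cc1` with 85.2% lies furthest, beyond it. Compound 4 `CCOC(=O)c1sc(-c2cccc(NC(=O)c3ccc(Cl)cc3)c2)nc1Nc1ccc(N2CCN(C)CC2)cc1` differs from compound 2 thus: chloro in place of tert-butyl on an aromatic carbon, on an aromatic carbon of a six-membered aromatic ring of carbon only, para to a large group. Two kinds of step bear on this. Exchanging groups at that same carbon gave a number 2.8 percentage points higher from compound 1 to compound 2 (within the scatter); moving to 3-fluorophenyl on the carbonyl carbon gave a number 64 percentage points higher from compound 2 to compound 3 (beyond the scatter) and a number 66.8 percentage points higher from compound 1 to compound 3 (beyond the scatter). Chloro keeps the substituent at the carbon shared by trifluoromethyl and tert-butyl, so in this assay a step near a number 8.8 percentage points higher from compound 2 to compound 4 (within the scatter) is expected, not clearly beyond the scatter. Compound 4 is therefore expected to give 30%, between 10% and 60%.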

Compound 4, a percentage reported as inhibition, at one concentration (the size of the read-out at that concentration, not a potency): 46.9%
For compound 4 the middle estimate is 16.9 percentage points below the measured one; the measured number falls inside the stated range.
By their numbers in this assay, from the lowest: compounds 1 and 2 (each within the scatter of the next); then compound 4; then compound 3.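

In this assay the group para to a large group does matter: chloro gives a number 25.7 percentage points higher from compound 2 to compound 4 (beyond the scatter) and, against trifluoromethyl, a number 28.5 percentage points higher from compound 1 to compound 4 (beyond the scatter) even though the earlier exchange at this carbon stayed within the scatter. The change at this carbon does not close the gap to the 3-fluorophenyl amide, as 4-chlorophenyl on the carbonyl carbon gives a number 38.3 percentage points lower from compound 3 to compound 4 (beyond the scatter) in the same read-out. Nothing measured here accounts for these steps. Open, as far as these compounds go, is what an amine or a carboxylic acid at this carbon would give.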